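Aryl for ester at the coumarin-type position: compound 4

The compounds below may be only part of what the source reports. "The series", "measured", "known", "first", "only" and "open" are said of these compounds alone.

Compound 3 `CCOC(=O)c1cc2ccc(OCCCCCn3cc(CNC(=O)CCCCC4CCSS4)nn3)cc2oc1=O` is the lowest of the three measured numbers in a functional assay on PC-12 cells (Rattus norvegicus) for cytotoxicity, read by MTT assay, with stated times of 3 h and 2 h, tested at 50 uM (a higher number here means a stronger effect of the compound at the concentration tested, a lower number a weaker effect), giving 40.7%. Compound 2 `Cc1cc(=O)oc2cc(OCCCCCn3cc(CNC(=O)CCCCC4CCSS4)nn3)ccc12` gives 73.7% in this assay, and compound 1 `O=C(CCCCC1CCSS1)NCc1cn(CCCCOc2ccc3cc(-c4ccc(Cl)cc4)c(=O)oc3c2)nn1` gives 74.9%, both gaps to compound 3 beyond the scatter. Compound 4 `COc1ccc(-c2cc3ccc(OCCCCCn4cc(CNC(=O)CCCCC5CCSS5)nn4)cc3oc2=O)cc1` is not yet measured. It differs from compound 3 in one place: 4-methoxyphenyl in place of ethoxycarbonyl on an aromatic carbon. Going by the values given here, no measured pair isolates this change. An upward step in this assay is expected, a number 29.3 percentage points higher from compound 3 to compound 4 (beyond the scatter), because compound 1 carries an aryl group at this position and gives 74.9%. Compound 4 is therefore estimated at 70% in this assay, with a range from 50% to 85%.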

Compound 4, a percentage reported as activity, at one concentration (the size of the read-out at that concentration, not a potency): 52.8%
Compound 4: middle estimate off by 17.2 percentage points, on the high side, within the range that was stated.
By their numbers in this assay, from the lowest: compound 3; then compound 4; then compounds 2 and 1 (each within the scatter of the next).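

In this assay, going by these compounds alone, 4-methoxyphenyl in place of ethoxycarbonyl on this aromatic carbon gives a number 12.1 percentage points higher from compound 3 to compound 4 (beyond the scatter), the first one-place reading at this position. The position therefore responds to the group it carries, though this single modest step says nothing about other groups there. No measurement bearing on the origin of the step is available.

Still open, from the compounds shown here alone, is whether the step comes from the aromatic ring or from its methoxy group. Unsubstituted phenyl, a carboxylic acid or an amine at this carbon would extend the comparison.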